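The source may report more compounds than this note shows. Statements on the series, on what has been measured and on what is new or still open speak of the compounds shown alone.

Compound 3 `Cc1ccccc1C(=O)Nc1ccc(S(=O)(=O)NC2CCN(C(=O)NC(C)C)CC2)c2ccccc12` gives 77.7 nM in an assay on L1.2 cells for binding affinity to C-C chemokine receptor type 8 (Homo sapiens) (on this read-out higher numbers stand for weaker inhibition and lower numbers for stronger inhibition), the highest of the three numbers measured. Compound 1 `CCC(=O)N1CCC(NS(=O)(=O)c2ccc(NC(=O)c3ccccc3C)c3ccccc23)CC1` gives 2.5 nM and compound 2 `COCC(=O)N1CCC(NS(=O)(=O)c2ccc(NC(=O)c3ccccc3C)c3ccccc23)CC1` gives 15.8 nM. The steps of a 31-fold higher number from compound 1 to compound 3 (1.49 log units; beyond the scatter) and a 4.9-fold higher number from compound 2 to compound 3 (0.69 log units; beyond the scatter) show that the group on this carbonyl carbon matters. Compound 4 `Cc1ccccc1C(=O)Nc1ccc(S(=O)(=O)NC2CCN(C(=O)N(C)C)CC2)c2ccccc12` differs from compound 3 by dimethylamino in place of isopropylamino on a carbonyl carbon, a smaller change than either measured step, which swapped a carbon group for a nitrogen group, and the urea stays in place. The expected step of a 1.3-fold lower number from compound 3 to compound 4 (0.11 log units; within the scatter) is therefore small and uncertain in direction. For compound 4 the estimate in this assay is 60 nM, with a range from 20 nM to 200 nM.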

Compound 4, inhibition constant: 1.6 nM
The estimate for compound 4 lay 38-fold (1.57 log units) above the measured number; the whole stated range lies above it.
By their numbers in this assay, from the lowest: compounds 4 and 1 (each within the scatter of the next); then compound 2; then compound 3.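

On this carbonyl carbon a urea is not in itself a loss in this assay: dimethylamino in place of isopropylamino gives a 49-fold lower number from compound 3 to compound 4 (1.69 log units; beyond the scatter), and isopropylamino carries a hydrogen-bond donor while dimethylamino carries none. Set against the carbon groups, dimethylamino gives a 9.9-fold lower number from compound 2 to compound 4 (0.99 log units; beyond the scatter) and a 1.6-fold lower number from compound 1 to compound 4 (0.19 log units; within the scatter), so it matches ethyl within the scatter. No measurement at hand explains the change. As far as these compounds go, whether the donor or the carbon groups on the nitrogen decide the result stays open; methylamino or pyrrolidin-1-yl on this carbonyl carbon would help tell them apart.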